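A few compounds are considered here, and "the series" means these few. Any claim that something is new, unique, unknown or untested is made for them only; others in the source may bear on it.

Working notes on the series, read in a functional assay on HGC cells (Homo sapiens) for cytotoxicity, read by MTT assay, with a stated time of 48 h; a lower number here means a stronger inhibitor, a higher number a weaker inhibitor. Compound 1 (`CCn1c(/C=C2/C(=O)Nc3ccc(F)cc32)nc2ccccc21`) gives > 50000 nM, which is a limit and not a number. Compound 3 (`CCn1c(/C=C2/C(=O)Nc3ccc(Br)cc32)nc2ccccc21`) gives > 50000 nM, which is also a limit. For the measured compounds named here, the only measured step is a step that the two limits leave unreadable from compound 1 to compound 3, with bromo in place of fluoro on an aromatic carbon. Compound 2 (`Cn1c(/C=C2/C(=O)Nc3ccc([N+](=O)[O-])cc32)nc2ccccc21`) has no single number, and its entry reads "not determined" (no result reported). The starting point therefore offers no value to step from, only the neighbouring results at the limit of > 50000 nM in this assay, at which 2 of the 3 values shown sit.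

The step to follow leads to compound 4 (`Cn1c(/C=C2/C(=O)Nc3ccc(F)cc32)nc2ccccc21`): fluoro in place of nitro on an aromatic carbon. This puts fluoro in place of nitro on an aromatic carbon of a six-membered aromatic ring of carbon only. Going by the values given here, no measured step involves the nitro group, and the one measured step has no readable size, so no step of definite size or direction is expected in this assay. Compound 4 is instead expected to stay in the region of the limit. That expectation rests on compound 1, which also carries fluoro and gives > 50000 nM, a limit. A report of only a limit is the likeliest outcome. For compound 4 the estimated value is 50000 nM, with an expected range of 20000 nM to 100000 nM.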

Compound 4, half-maximal inhibitory concentration: 37800 nM
Compound 4: middle estimate off by 1.3-fold (0.12 log units), on the high side; measured number inside the range.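

In this assay compound 4 gives 37800 nM, the first result in the series that is a number and not a limit, so a fluoro compound of this core can be read in this assay when hydrogen stands in place of methyl on the saturated chain carbon bound to the aromatic nitrogen. Compound 1, which keeps that methyl, gives > 50000 nM, and this is a limit. The change at that chain is an at least 1.3-fold lower number from compound 1 to compound 4 (0.12 log units; that floor lies within the scatter), so it is not shown to go beyond the scatter, and the series as shown stays close to the limit: the limit of > 50000 nM in this assay, at which 2 of the 4 values shown sit.

The steps from compound 1 to compound 3 and from compound 2 to compound 4 cannot be read, so neither bromo in place of fluoro nor fluoro in place of nitro has a size. Also open, as far as these compounds go, is whether an amine or a carboxylic acid on the aromatic carbon that carries fluoro, or a longer chain on the aromatic nitrogen, would give a number clearly lower than that of compound 4.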